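Swapping an Amide Side Chain for an Aryl Amidine

The source may report more compounds than this note shows. Statements on the series, on what has been measured and on what is new or still open speak of the compounds shown alone.

Of the compounds shown here, three sharing one fused core have been tested in a functional assay on the whole organism (strain albino) for inhibition, with Rattus norvegicus as the target, read by paw edema, with a stated time of 1 h, at a dose of 20 mmol/kg by the intraperitoneal route; on this read-out higher numbers stand for more inhibition at the one dose given (going by the name of the read-out) and lower numbers for less inhibition. Compound 1 `N#CC1=C(NCC(=O)N2CCOCC2)N(c2ccccc2)C(=O)N2CCCCC(N3CCCC3)C12` gives 43.9% in this assay, which places it second highest of the three. Compound 2 `N#CC1=C(NCC(=O)O)N(c2ccccc2)C(=O)N2CCCCC(N3CCCC3)C12` gives 67.2%, and compound 3 `N#CC1=C(/N=C/Nc2ccc([N+](=O)[O-])cc2)N(c2ccccc2)C(=O)N2CCCCC(N3CCCC3)C12` gives 32.1%. The step of a number 23.3 percentage points higher from compound 1 to compound 2 (beyond the scatter) shows the gain when a hydroxy replaces the morpholin-4-yl on the carbonyl carbon, while a number 11.8 percentage points lower from compound 1 to compound 3 (beyond the scatter) and a number 35.1 percentage points lower from compound 2 to compound 3 (beyond the scatter) show losses when the aryl amidine enters.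

Compound 4 `COc1ccc(N/C=N/C2=C(C#N)C3C(N4CCCC4)CCCCN3C(=O)N2c2ccccc2)cc1` is not yet measured. It differs from compound 1 by a group of 11 heavy atoms (8 carbon, 2 nitrogen, 1 oxygen; one six-membered aromatic ring of carbon only) in place of a group of 10 heavy atoms (6 carbon, 2 nitrogen, 2 oxygen; one six-membered non-aromatic ring with 2 hetero atoms), on a double-bonded ring carbon

The change most like this one is the step from compound 1 to compound 3, where a related aryl amidine entered in the same place and gave a number 11.8 percentage points lower from compound 1 to compound 3 (beyond the scatter). Compound 4 carries a methoxy on its aromatic ring where compound 3 carries a nitro group, and nothing in the data shows how that difference matters. A modest drop of about the same size is therefore expected, a number 9.9 percentage points lower from compound 1 to compound 4 (within the scatter). In this assay compound 4 is estimated to give 34%, with a likely range from 20% to 48%.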

Compound 4, a percentage reported as inhibition, in the whole organism at one dose (the size of the read-out at that dose, not a potency): 20.6%
For compound 4 the middle estimate is 13.4 percentage points above the measured one; the range from low to high includes it.
By their numbers in this assay, from the lowest: compound 4; then compound 3; then compound 1; then compound 2.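

In this assay the new result shows that the group on the aromatic ring of the aryl amidine is not a neutral detail: methoxy in place of nitro gives a number 11.5 percentage points lower from compound 3 to compound 4 (beyond the scatter) and so moves the read-out by more than the usual scatter. The second aryl amidine also confirms the loss against the morpholine amide, with a number 23.3 percentage points lower from compound 1 to compound 4 (beyond the scatter) at this double-bonded ring carbon, and the distance to the best compound shown grows to a number 46.6 percentage points lower from compound 2 to compound 4 (beyond the scatter) in this series of four. No measurement at hand bears on why methoxy ends up lower than nitro here, so the step stands as an observation without an explanation.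

Going by these compounds, it remains open how other groups on that aromatic ring, such as a chloro or an amino group, or the bare phenyl ring itself, would compare with methoxy and nitro. Also open, on these data alone, is whether a longer chain ending in a carboxylic acid, or a simple amine, on the double-bonded ring carbon would hold on to the high number of compound 2, which gives 67.2% in this assay.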